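Ring halogen swap on the benzylamide of the succinimide series

The source may report more compounds than this note shows. Statements on the series, on what has been measured and on what is new or still open speak of the compounds shown alone.

Measured compounds:
- compound 1, `CC1CC(=O)N(C(C)C(=O)NCc2ccccc2Cl)C1=O`: 85.9 mg/kg
- compound 2, `CC1CC(=O)N(C(C)C(=O)NCc2cccc(Cl)c2)C1=O`: 90.3 mg/kg

In a functional assay on the whole organism (strain Albino Swiss CD1) with Mus musculus as the target, in the maximal electroshock model (on this read-out lower numbers stand for an effect already at smaller amounts and higher numbers for an effect only at larger amounts of compound), compound 2 gives 90.3 mg/kg and holds the highest of the two numbers at hand; its nearest neighbour is compound 1, separated by a 1.1-fold higher number from compound 1 to compound 2 (0.02 log units; within the scatter), a gap within the scatter. Compound 3, `CC1CC(=O)N(C(C)C(=O)NCc2ccccc2F)C1=O`, has not yet been measured in this assay. The change from compound 2 to compound 3 is 2-fluorophenyl in place of 3-chlorophenyl on a saturated chain carbon bound to an amide-type nitrogen: the halogen on the ring changes from chlorine to fluorine and its position on the ring changes at the same time.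

Going by the values given here, only one measured step exists, the one from compound 1 to compound 2, which moved the chlorine on the ring and stayed within the scatter. Among the compounds with values here, no measured step covers an exchange of chlorine for fluorine on this ring, so the expectation rests on the single position step alone. The step from compound 2 to compound 3 is therefore expected to be a 1.1-fold lower number from compound 2 to compound 3 (0.03 log units; within the scatter), not beyond the scatter in either direction. Compound 3 is estimated at 85 mg/kg, with a range from 45 mg/kg to 170 mg/kg.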

Compound 3, dose for half-maximal effect: 80.5 mg/kg
Compound 3: middle estimate off by 1.1-fold (0.02 log units), on the high side; low and high end bracket the measured number.
By their numbers in this assay, from the lowest: compounds 3, 1 and 2 (each within the scatter of the next).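

In this assay, fluoro in place of chloro on an aromatic carbon can now be read directly: a 1.1-fold lower number from compound 1 to compound 3 (0.03 log units; within the scatter). This is an exchange of the halogen itself, whereas the earlier pair only differed in where the chlorine sat on the ring. The combined change, 2-fluorophenyl in place of 3-chlorophenyl on a saturated chain carbon bound to an amide-type nitrogen, gives a 1.1-fold lower number from compound 2 to compound 3 (0.05 log units; within the scatter), so among these three compounds neither the halogen exchange alone nor the exchange combined with a different ring position leaves the scatter, and no supporting data are at hand to interpret these steps.

All three compounds carry a halogen on this ring, so they do not show whether the halogen matters at all, or whether a methoxy, a trifluoromethyl or an amine at this place would give a number outside the scatter of this group. The shared core is also constant across the three, which leaves open what its methyl groups contribute and how a longer chain in their place would read out.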